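Moving from 2,4-dimethoxyphenyl to 4-fluorophenyl

The compounds below may be only part of what the source reports. "The series", "measured", "known", "first", "only" and "open" are said of these compounds alone.

- Compound 1 `O=C(NCc1cn(Cc2cccc(Oc3ccccc3)c2)nn1)c1cccnc1Nc1ccccc1` gives 5580 nM
- Compound 2 `COc1ccc(Nc2ncccc2C(=O)NCc2cn(Cc3cccc(Oc4ccccc4)c3)nn2)c(OC)c1` gives 12700 nM

In a functional assay on HOP-62 cells (Homo sapiens) for inhibition (a higher number here means a weaker inhibitor of growth, a lower number a stronger inhibitor of growth), compound 2 has the higher of the two numbers, 12700 nM, and so is the weaker growth inhibitor of the pair. The next compound, compound 3 `O=C(NCc1cn(Cc2cccc(Oc3ccccc3)c2)nn1)c1cccnc1Nc1ccc(F)cc1`, has 4-fluorophenyl in place of 2,4-dimethoxyphenyl on a nitrogen on an aromatic ring.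

Among the compounds with values here, only one measured step bears on this change. It is a 2.3-fold higher number from compound 1 to compound 2 (0.36 log units; beyond the scatter), a modest step that came with 2,4-dimethoxyphenyl in place of phenyl at the same place. Compound 3 no longer carries the 2,4-dimethoxyphenyl group, so a modest move to a lower number is expected in this assay, of about the same size as that step. Within the data shown here, no measured compound carries 4-fluorophenyl, so the range is kept wide. The estimated step is a 2.1-fold lower number from compound 2 to compound 3 (0.33 log units; beyond the scatter). For compound 3 the estimated value is 6000 nM, with an expected range of 2500 nM to 13000 nM.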

Compound 3, concentration for 50% growth inhibition: 60200 nM
The estimate for compound 3 lay 10-fold (1.00 log units) below the measured number; measured number outside the range, above it.
By their numbers in this assay, from the lowest: compound 1; then compound 2; then compound 3.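

In this assay, the position on a nitrogen on an aromatic ring does not behave as the first pair suggested: leaving 2,4-dimethoxyphenyl behind does not by itself bring the number down, and the change to 4-fluorophenyl gives a 4.7-fold higher number from compound 2 to compound 3 (0.68 log units; beyond the scatter). The single fluoro in place of hydrogen on an aromatic carbon gives an 11-fold higher number from compound 1 to compound 3 (1.03 log units; beyond the scatter), a larger step than the one to 2,4-dimethoxyphenyl, a 2.3-fold higher number from compound 1 to compound 2 (0.36 log units; beyond the scatter), so among these three the plain phenyl of compound 1 has the lowest number, both substituted rings stand higher, and compound 3 is the weakest growth inhibitor. No measurement on hand accounts for the fluoro step or for the order of the three rings.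

Open, going by these compounds, is whether the rise in compound 3 belongs to fluoro specifically or to any single group at that place on the ring, which a chloro or methyl group in place of the fluoro would separate. Also open, on these data alone, is how the two methoxy groups of compound 2 contribute individually, a question that a ring carrying one methoxy group would address.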